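Thioether series notes: step from compound 3 to compound 4

A few compounds are considered here, and "the series" means these few. Any claim that something is new, unique, unknown or untested is made for them only; others in the source may bear on it.

Measured so far:
Compound 1 `CCOc1ccc(-c2c(C#N)c(N)nc(SCc3ccn[nH]3)c2C#N)cc1`: 332 nM
Compound 2 `CC(=O)Nc1ccc(-c2c(C#N)c(N)nc(SCC(N)=O)c2C#N)cc1`: 164 nM
Compound 3 `N#Cc1c(N)nc(SCC(=O)NCO)c(C#N)c1-c1ccc(OCC2CC2)cc1`: 182 nM

In a functional assay on CHO cells for agonist activity at adenosine receptor A2b (Homo sapiens), read by AlphaScreen and cAMP accumulation (a lower number here means that less compound is needed, a higher number that more compound is needed for the effect), compound 3 gives 182 nM and stands second highest of the three numbers, though its gaps to compound 2 and to compound 1 both lie within the scatter. Compound 4 `N#Cc1c(N)nc(SCc2ncc[nH]2)c(C#N)c1-c1ccc(OCC2CC2)cc1` has not been measured. It differs from compound 3 by 1H-imidazol-2-yl in place of (hydroxymethyl)carbamoyl on a saturated chain carbon bound to a sulfur. Among the compounds with values here, no step between measured compounds is available for this change, and the three values so far all sit within the scatter of one another. The step in this assay from compound 3 to compound 4 is expected to be small, likely towards a slightly higher number, and not clearly beyond the scatter, as a 1.4-fold higher number from compound 3 to compound 4 (0.14 log units; within the scatter). Compound 4 is estimated at 250 nM in this assay, with a range from 90 nM to 700 nM.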

Compound 4, half-maximal effective concentration: 9.5 nM
For compound 4 the middle estimate is 26-fold (1.42 log units) above the measured one; measured number below the stated range.
By their numbers in this assay, from the lowest: compound 4; then compounds 2, 3 and 1 (each within the scatter of the next, the first and the last beyond it).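

On the saturated chain carbon bound to a sulfur, 1H-imidazol-2-yl in place of (hydroxymethyl)carbamoyl gives a 19-fold lower number from compound 3 to compound 4 (1.28 log units; beyond the scatter) in this assay. Within the data shown here, this is the first reading of a single change, and it shows that the group at this position can shift the number far beyond the scatter. No available measurement accounts for the step. Still open, going by these compounds, is whether a pyridine ring, a primary amine or a longer chain at this place would keep the low number of compound 4, and whether the step holds with another group in place of the cyclopropylmethoxy.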